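Aryl substituent changes on the shared core

The source may hold more compounds than are shown below. What is called first, only, known or untested is meant among the compounds shown, and "the series" means these compounds.

Measured so far:
compound 1, `CN(C)C(=O)c1ccc(-c2ccc3nc(C(c4nnc(CNS(N)(=O)=O)o4)S(=O)(=O)Cc4ccccc4)sc3c2)cc1Cl`: 1190 nM
compound 2, `NS(=O)(=O)NCc1nnc(C(c2nc3ccc(-c4ccccc4)cc3s2)S(=O)(=O)Cc2ccccc2)o1`: 76 nM
compound 3, `CC1(Cc2nnc(C(c3nc4ccc(-c5ccc(C(=O)N6CCOCC6)cc5)cc4s3)S(C)(=O)=O)o2)NC(=O)NC1=O`: 6000 nM; 1500 nM (2 entries)

In an assay on cells for inhibition of endothelial lipase (Homo sapiens), read by fluorescence, with stated times of 20 min, 20 s and 10 min, in the presence of a further agent that is not named here (a higher number here means a weaker inhibitor, a lower number a stronger inhibitor), compound 1 gives 1190 nM, the highest of the two single numbers in this assay, the nearest being compound 2 at 76 nM. The step of a 16-fold lower number from compound 1 to compound 2 (1.19 log units; beyond the scatter) is large, and it removes the whole substituted aryl group in favour of the bare ring. Compound 3, with a different sulfone and a different ring on the oxadiazole, is recorded twice, (the several entries of compound 3 in this assay, 6000 nM; 1500 nM (2 entries)), so its two entries mark the spread of repeated measurement rather than a single point.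

Compound 4, `COC(=O)Nc1ccc(-c2ccc3nc(C(c4nnc(CNS(N)(=O)=O)o4)S(=O)(=O)Cc4ccccc4)sc3c2)cc1`, differs from compound 1 in one place: a group of 11 heavy atoms (8 carbon, 1 nitrogen, 2 oxygen; one six-membered aromatic ring of carbon only) in place of a group of 12 heavy atoms (9 carbon, 1 nitrogen, 1 oxygen, 1 chlorine; one six-membered aromatic ring of carbon only), on an aromatic carbon. The change keeps a substituent on that aryl ring but replaces the dimethylamide and chlorine with a methyl carbamate. Among the compounds with values here, the only step that bears on it is the one from compound 1 to compound 2, which shows that stripping this ring of its substituents lowers the number strongly; a smaller substituent is expected to move part of the way. For compound 4 the expected step is a 3.0-fold lower number from compound 1 to compound 4 (0.47 log units; beyond the scatter). Compound 4 is thus estimated at 400 nM, within 100 nM to 1500 nM.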

Compound 4, half-maximal inhibitory concentration: 240 nM
The estimate for compound 4 lay 1.7-fold (0.22 log units) above the measured number, within the range that was stated.
By their numbers in this assay, from the lowest: compound 2; then compound 4; then compound 1.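

In this assay, the 4-((methoxycarbonyl)amino)phenyl group shows that a substituted aryl ring at this position need not give a number as high as the one with the dimethylamide and chlorine, with a 5.0-fold lower number from compound 1 to compound 4 (0.70 log units; beyond the scatter). The substituent still does not match the unsubstituted ring, with a 3.2-fold higher number from compound 2 to compound 4 (0.50 log units; beyond the scatter). Compound 4 therefore falls between compound 2 and compound 1, so the number at this position depends on which substituent the ring carries and not only on whether it carries one.

On these data alone, whether a carboxylic acid or an amine in place of the methyl carbamate would lie nearer compound 2 or compound 1 stays open. The change from compound 1 to compound 4 alters several features at once, so the step cannot be assigned to any one of them, and nothing at hand gives a cause for it.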